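Swapping an Amino Linker for a Thioether Linker

A few compounds are considered here, and "the series" means these few. Any claim that something is new, unique, unknown or untested is made for them only; others in the source may bear on it.

Compound 1 `COc1ccc(-c2nc(CNc3cccc(Cl)c3)nc3ccsc23)cn1` in an ADME assay on cells (Homo sapiens) for cytotoxicity, read by resazurin assay, with a stated time of 5 days (a lower number here means that less compound is tolerated, a higher number that more compound is tolerated), gives > 50000 nM, a limit of the assay rather than a number. Compound 2 `COc1ccc(-c2nc(CSc3ccc(C(F)(F)F)cn3)nc3ccsc23)cn1` gives > 50000 nM in this assay, again a limit. Compound 3 `COc1ccc(-c2nc(CS(=O)(=O)c3cccc(Cl)c3)nc3ccsc23)cn1` gives > 10000 nM in this assay, also a limit.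

So compound 1 does not stand at a measured number at all: its result sits at the limit of > 50000 nM in this assay, at which 2 of the 3 values shown sit, and no value in this set is a true number, since the remaining result sits at the limit of > 10000 nM in this assay, at which 1 of the 3 values shown sits. Every compound shown was tolerated by the cells up to the highest concentration tested.

Compound 4 `COc1ccc(-c2nc(CSCc3cccc(Cl)c3)nc3ccsc23)cn1` differs from compound 1 in one place: (3-chlorobenzyl)sulfanyl in place of (3-chlorophenyl)amino on a saturated chain carbon bound to an aromatic carbon. Going by the values given here, no step between two measured compounds is available here, so the size of this change cannot be read from the data. All three measured results sit at a limit of this assay. Compound 4 is expected to behave in the same way, with the step of a number no higher from compound 1 to compound 4 (the limit leaves the size open) expected to lie within the scatter. Compound 4 is therefore estimated at 50000 nM, within 15000 nM to 150000 nM, most likely reported again as a limit.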

Compound 4, half-maximal cytotoxic concentration: > 50000 nM
Compound 4: a limit, no number; the forecaster's own chance of this, stated with the estimate: 85%; the middle value lies on the limit itself.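

Compound 1 and compound 4 both give only a limit in this assay, not a number, so the step between them cannot be read. The compounds shown leave open what concentration the cells fail to tolerate, and whether (3-chlorobenzyl)sulfanyl and (3-chlorophenyl)amino differ at all.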